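Replacing Propyl by Pentylamino on the Carbonyl Carbon

A few compounds are considered here, and "the series" means these few. Any claim that something is new, unique, unknown or untested is made for them only; others in the source may bear on it.

Measured compounds in a functional assay on MCF7 cells (Homo sapiens) for antiproliferative activity, read by sulforhodamine B assay, with a stated time of 48 h; on this read-out lower numbers stand for stronger inhibition and higher numbers for weaker inhibition:
Compound 1, `CCCC(=O)Nc1ccc(S(=O)(=O)Oc2ccccc2C(C)C)cc1`, gives 6600 nM.
Compound 2, `CCCC(=O)Nc1ccc(S(=O)(=O)Oc2ccccc2I)cc1`, gives 9700 nM.
Compound 3, `CC(C)c1ccccc1OS(=O)(=O)c1ccc(NC(=O)CCCCl)cc1`, gives 5200 nM.

Compound 2 sits among three numbers that all lie within the usual scatter of one another: the step of a 1.5-fold higher number from compound 1 to compound 2 (0.17 log units; within the scatter) and the step of a 1.3-fold lower number from compound 1 to compound 3 (0.10 log units; within the scatter) are both small, and the numbers of compound 2 and compound 3 differ from each other by no more than that scatter allows. Nothing in these three compounds therefore separates one from another with confidence.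

Compound 4, `CCCCCNC(=O)Nc1ccc(S(=O)(=O)Oc2ccccc2I)cc1`, has not yet been measured. It differs from compound 2 by pentylamino in place of propyl on a carbonyl carbon. Neither measured step touches this part of the molecule: the step from compound 1 to compound 2 exchanges groups on the aromatic carbon, and the step from compound 1 to compound 3 alters the saturated chain, and both stay within the scatter. There is no measured change at the carbonyl carbon to draw on, so the expectation rests only on the observation that every alteration seen so far has left the number essentially unchanged.

On that basis compound 4 is expected to give 8500 nM in this assay, within a range of 3000 nM to 25000 nM. The expected step of a 1.1-fold lower number from compound 2 to compound 4 (0.06 log units; within the scatter) is estimated to stay within the scatter, with no direction favoured.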

Compound 4, half-maximal inhibitory concentration: 5400 nM
Beside the measured number, compound 4's estimate is 1.6-fold (0.20 log units) above it; measured number inside the range.
By their numbers in this assay, from the lowest: compounds 3, 4, 1 and 2 (each within the scatter of the next).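

Among the compounds shown here, the carbonyl carbon is the first place where a change can be read, and in this assay the exchange of propyl for pentylamino gives a 1.8-fold lower number from compound 2 to compound 4 (0.25 log units; within the scatter). The entering group brings a longer chain, with a nitrogen and a hydrogen-bond donor that propyl lacks, and this swap of propylcarbonyl for pentylcarbamoyl on the shared core still leaves the number within the scatter, as with the earlier exchanges on the aromatic carbon and the saturated chain. The compounds shown therefore give no sign that this position controls the antiproliferative number, and nothing available accounts for the result or bears on its cause.

This single pair cannot separate the contribution of the added nitrogen from that of the longer chain, so butylamino, a chain of another length joined directly to the carbonyl carbon, or a terminal carboxylic acid or amine on the pentyl chain would each test a different part of the exchange. From the compounds shown here alone, it also remains open whether pentylamino gives a comparable step when isopropyl stands in place of iodo on the aromatic carbon.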